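The source may hold more compounds than are shown below. What is called first, only, known or untested is meant among the compounds shown, and "the series" means these compounds.

Measured so far in a functional assay on the whole organism (strain Wistar albino) for inhibition, with Rattus norvegicus as the target, read by paw edema, with a stated time of 3 h, at a dose of 25 mg/kg by the oral route; a lower number here means less inhibition, a higher number more inhibition at the dose given (going by the name of the read-out):
compound 1 `O=c1c2c(Nc3ccccc3)nn(-c3ccccc3)c2nc(Nc2ccccc2)n1-c1ccccc1`, 17.1%
compound 2 `O=c1c2c(Nc3ccc([N+](=O)[O-])cc3)nn(-c3ccccc3)c2nc(Nc2ccccc2)n1-c1ccccc1`, 15.1%
compound 3 `NS(=O)(=O)c1ccc(-n2nc(Nc3ccc([N+](=O)[O-])cc3)c3c(=O)n(-c4ccccc4)c(Nc4ccccc4)nc32)cc1`, 39.1%

Compound 2 is the lowest of the three numbers shown, though only nominally against compound 1: a number 2 percentage points lower from compound 1 to compound 2 (within the scatter), whereas a number 24 percentage points higher from compound 2 to compound 3 (beyond the scatter). Compound 4 `O=c1c2c(Nc3ccc(Cl)cc3)nn(-c3ccccc3)c2nc(Nc2ccccc2)n1-c1ccccc1` has not yet been measured in this assay. It differs from compound 2 by chloro in place of nitro on an aromatic carbon. Among the compounds with values here, the one measured step at that position is a number 2 percentage points lower from compound 1 to compound 2 (within the scatter), so nitro against hydrogen there made no difference beyond the scatter. The step of a number 24 percentage points higher from compound 2 to compound 3 (beyond the scatter) concerns a different position and does not bear on this change. Within the data shown here, no measured step involves chloro. For compound 4 a step within the scatter is therefore expected, a number 0.9 percentage points higher from compound 2 to compound 4 (within the scatter). Compound 4 is estimated at 16% in this assay, between 8% and 26%.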

Compound 4, a percentage reported as inhibition, in the whole organism at one dose (the size of the read-out at that dose, not a potency): 28.7%
Compound 4: the middle estimate sits 12.7 percentage points below what was measured; the measured number lies above the stated range.
By their numbers in this assay, from the lowest: compounds 2 and 1 (each within the scatter of the next); then compound 4; then compound 3.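

In this assay the group on this phenyl ring does matter: chloro in place of nitro reads as a number 13.6 percentage points higher from compound 2 to compound 4 (beyond the scatter) and chloro in place of hydrogen as a number 11.6 percentage points higher from compound 1 to compound 4 (beyond the scatter) on the same core. The position therefore responds to a change of group, which the nitro against hydrogen step alone did not show. Nothing measured accounts for chloro standing apart from nitro and hydrogen.

On these data alone, whether this step is particular to chloro remains open, and bromo, methoxy or an amine in the same place would test that. Also open, as far as these compounds go, is whether chloro and sulfamoyl together would add up.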